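Notes on a pyridylmethyl to thienylmethyl swap

The compounds below may be only part of what the source reports. "The series", "measured", "known", "first", "only" and "open" are said of these compounds alone.

Three compounds of one series have numbers in an assay on CHO cells for displacement of a labelled ligand from adenosine receptor A1 (Homo sapiens), read by scintillation counting, with a stated time of 90 min; a lower number here means a stronger inhibitor, a higher number a weaker inhibitor. Compound 2 `Nc1nc(NCc2cccnc2)nc2sc(-c3ccco3)nc12` gives 7.12 nM in this assay. Compound 1 `Nc1nc(NCc2cccs2)nc2sc(-c3cccs3)nc12` gives 73 nM, and compound 3 `COc1cccc(CNc2nc(N)c3nc(-c4ccc(C)o4)sc3n2)c1` gives 70 nM. Compound 2 thus stands at the lowest number of the three, and its gaps to compound 3 and to compound 1 both lie beyond the scatter; compound 1 and compound 3 give numbers close to each other. For the measured compounds named here, each of those two differs from compound 2 in more than one place, so no single step between measured compounds is available.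

Compound 4 `Nc1nc(NCc2ccsc2)nc2sc(-c3ccco3)nc12` is the next one to be measured in this assay. It differs from compound 2 as follows: thiophen-3-yl in place of pyridin-3-yl on a saturated chain carbon bound to a nitrogen on an aromatic ring. Going by the values given here, no measured pair shows this difference, so the size of the step can only be guessed from the spread of the three numbers. The step is expected to be a small loss, a 2.1-fold higher number from compound 2 to compound 4 (0.32 log units; beyond the scatter), though a result within the scatter would not surprise. In this assay compound 4 is expected at 15 nM, in the range 5 nM to 50 nM.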

Compound 4, inhibition constant: 8.12 nM
Compound 4: middle estimate off by 1.8-fold (0.27 log units), on the high side; measured number inside the range.
By their numbers in this assay, from the lowest: compounds 2 and 4 (each within the scatter of the next); then compounds 3 and 1 (each within the scatter of the next).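

In this assay thiophen-3-yl in place of pyridin-3-yl on a saturated chain carbon bound to a nitrogen on an aromatic ring gives a 1.1-fold higher number from compound 2 to compound 4 (0.06 log units; within the scatter) and leaves the rest of the structure unchanged. This first single-place step shows that, in this pair, a five-membered aromatic ring with sulfur can replace a six-membered aromatic ring with nitrogen at this position without a change beyond the scatter. No measurement here bears on why the two compounds read alike.

On these data alone, whether this holds when the other substituent on the shared core also changes stays open, since compound 1 and compound 3 differ from compound 4 in more than one place. Also open, as far as these compounds go, is how this position responds to a cyclohexyl group or a longer chain.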